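The source may report more compounds than this note shows. Statements on the series, on what has been measured and on what is new or still open speak of the compounds shown alone.

Measured in a functional assay on DU-145 cells (Homo sapiens) for antiproliferative activity, read by sulforhodamine B assay, with a stated time of 3 days; on this read-out lower numbers stand for stronger inhibition of growth and higher numbers for weaker inhibition of growth:
- Compound 1 `O=C(Nc1cccc(Nc2ncc(F)c(Nc3ccc(F)cc3)n2)c1)c1ccncc1`: 4330 nM
- Compound 2 `O=C(Nc1cccc(Nc2ncc(F)c(Nc3ccc(F)cc3)n2)c1)c1ccccc1`: > 10000 nM

Compound 2 gives > 10000 nM, which is a limit of the assay and not a number. Its exact place on the scale is therefore unknown.

Compound 3 `O=C(Nc1cc(Cl)cc(Cl)c1)c1cccc(Nc2ncc(F)c(Nc3ccc(F)cc3)n2)c1` carries (3,5-dichlorophenyl)carbamoyl in place of benzamido on an aromatic carbon.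

For the measured compounds named here, only one measured step bears on this change: an at least 2.3-fold higher number from compound 1 to compound 2 (0.36 log units; beyond the scatter). Going by the values given here, it swaps a different group, so it shows only that a change in this part of the molecule can move the read-out beyond the scatter. Among the compounds with values here, no measured compound tests the new group, so no large step is expected in either direction.

The nearest exact number is that of compound 1, at 4330 nM, and the low end of the range is set near it. The expected change is an at least 1.1-fold lower number from compound 2 to compound 3 (0.04 log units; that floor lies within the scatter). Compound 3 is estimated at 9000 nM, with an expected range from 3000 nM to 25000 nM.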

Compound 3, concentration for 50% growth inhibition: 17500 nM
Compound 3: middle estimate off by 1.9-fold (0.29 log units), on the low side, within the range that was stated.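

In this assay, putting (3,5-dichlorophenyl)carbamoyl where compound 1 has ((pyridin-4-yl)carbonyl)amino gives a 4.0-fold higher number from compound 1 to compound 3 (0.61 log units; beyond the scatter). This adds a second replacement at this position with a readable comparison to compound 1, and like the phenyl replacement it moves the number up, towards weaker inhibition of growth, not down. Compound 2 has a limit and not a number, so its step to compound 3 cannot be read: the limit of > 10000 nM in this assay, at which 1 of the 3 values shown sits.

The change from compound 1 to compound 3 swaps the ring and its two chlorine atoms as well as the linking amide, so these compounds cannot say which of them carries the step. A plain phenylcarbamoyl group would help separate them, and a morpholine or a carboxylic acid on the ring remains an untested kind of group here.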